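Thiourea series: cytotoxicity on MDBK cells, aryl exchange

This account rests on a few compounds, and the source may have more. Where it says the series, first, only, none or still open, it means among the compounds named here.

Measured compounds:
compound 1, `FC(F)(F)c1cccc(NC(=S)Nc2cccc(Br)c2)c1`: 10000 nM
compound 2, `FC(F)(F)c1cccc(NC(=S)Nc2ccc(Cl)cc2)c1`: 17000 nM
compound 3, `C=C(C)CNC(=S)Nc1cccc(C(F)(F)F)c1`: > 100000 nM

In an ADME assay on MDBK cells (Bos taurus) for cytotoxicity, read by MTT assay, with a stated time of 96 h (a higher number here means that more compound is tolerated, a lower number that less compound is tolerated), compound 1 gives 10000 nM and compound 2 gives 17000 nM. For compound 3 the result is a limit of this assay, > 100000 nM; the same limit is the subject of the limit of > 100000 nM in this assay, at which 1 of the 3 values shown sits. Among the two numbers compound 2 stands highest, with compound 1 nearest: a 1.7-fold higher number from compound 1 to compound 2 (0.23 log units; within the scatter). The other two steps, an at least 10-fold higher number from compound 1 to compound 3 (1.00 log units; beyond the scatter) and an at least 5.8-fold higher number from compound 2 to compound 3 (0.76 log units; beyond the scatter), exchange an aryl group for 2-methylprop-2-en-1-yl and so do not describe an aryl-to-aryl change.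

Compound 4, `CCOC(=O)c1ccc(NC(=S)Nc2cccc(C(F)(F)F)c2)cc1`, is to be measured in this assay. It differs from compound 2 by ethoxycarbonyl in place of chloro on an aromatic carbon. Among the measured compounds shown here, the only step that bears directly on a substituent swap within the aryl ring is a 1.7-fold higher number from compound 1 to compound 2 (0.23 log units; within the scatter), which stayed within the scatter; the two steps to compound 3 concern a different kind of change and are set aside. A step of no more than the scatter is therefore expected, with a slight lean toward a higher number. Compound 4 is estimated at 20000 nM, between 8000 nM and 50000 nM, which would mean an expected 1.2-fold higher number from compound 2 to compound 4 (0.07 log units; within the scatter).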

Compound 4, half-maximal cytotoxic concentration: 64000 nM
For compound 4 the middle estimate is 3.2-fold (0.51 log units) below the measured one; the whole stated range lies below it.
By their numbers in this assay, from the lowest: compounds 1 and 2 (each within the scatter of the next); then compound 4. At a limit, above all of these: compound 3.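

In this assay, ethoxycarbonyl in place of chloro on an aromatic carbon, para to a large group, gives a 3.8-fold higher number from compound 2 to compound 4 (0.58 log units; beyond the scatter), so the substituent at this place on the aryl ring can move the number beyond the scatter while the rest of compound 2 stays the same. The earlier aryl-to-aryl step, a 1.7-fold higher number from compound 1 to compound 2 (0.23 log units; within the scatter), stayed within the scatter, and so gave no sign of this; the new step is the first among the aryl compounds shown to exceed it, although it is only modest in size. This reading rests on a single pair, one chloro and one ethoxycarbonyl compound, and no measurement shown here accounts for the step.

The compounds shown leave open whether the step belongs to the ester as such, which a carboxylic acid, a primary amide or a methoxycarbonyl group at the same place would begin to separate from the effect of simply having a longer substituent there. They also leave open whether a longer ester chain would continue the same direction, or whether the same exchange would give a similar step with a bromo group in place of the chloro.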